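This account rests on a few compounds, and the source may have more. Where it says the series, first, only, none or still open, it means among the compounds named here.

Compound 3, `Cn1c(-c2ccc(Cl)cc2)cnc1NC(=O)c1ncc[nH]1`, stands lowest of the three compounds measured in an ADME assay on microsomes from liver (Mus musculus) for metabolic stability (on this read-out lower numbers stand for slow clearance and higher numbers for fast clearance), where compound 3 gives 41 uL/min. Compound 1, `COc1ccc(-c2cnc(NC(=O)c3ncc[nH]3)n2C)cc1`, gives 511 uL/min in this assay, and compound 2, `COc1ccc(-c2cnc(NC(=O)c3ccc(F)cc3)n2C)cc1`, gives 396 uL/min; the difference of compound 1 from compound 2 is a 1.3-fold lower number from compound 1 to compound 2 (0.11 log units; within the scatter). The step that carries compound 1 to compound 3 is a 12-fold lower number from compound 1 to compound 3 (1.10 log units; beyond the scatter), so changing the group on the aromatic carbon of the outer ring is the one alteration seen here to move the read-out beyond the scatter.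

Compound 4, `Cn1c(-c2ccccc2)cnc1NC(=O)c1ncc[nH]1`, is not yet measured. It differs from compound 3 in this way: hydrogen in place of chloro on an aromatic carbon. Within the data shown here, no measured pair shows hydrogen against chloro at that carbon, so only the step from compound 1 to compound 3 bears on it, and it shows the group at that place matters. The account therefore expects the number to climb again, though less than the full span back to compound 1, an expected step of a 3.2-fold higher number from compound 3 to compound 4 (0.50 log units; beyond the scatter). For compound 4 the estimated value is 130 uL/min, within a range of 45 uL/min to 380 uL/min.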

Compound 4, intrinsic clearance in a liver preparation (reported as CLH), per the amount of preparation that the assay uses: > 866 uL/min
Compound 4 gave a limit, no number; the forecaster's own chance of this, stated with the estimate: 0%; at least 6.6-fold (0.82 log units) between middle value and limit.
By their numbers in this assay, from the lowest: compound 3; then compounds 2 and 1 (each within the scatter of the next). At a limit, above all of these: compound 4.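

Hydrogen in place of chloro on this aromatic carbon gives an at least 21-fold higher number from compound 3 to compound 4 (1.32 log units; beyond the scatter), so the low number of compound 3 goes with the chloro itself and not simply with the loss of methoxy. In this assay compound 4 gives > 866 uL/min, which is a limit of the assay and not a number. Hydrogen in place of methoxy gives an at least 1.6-fold higher number from compound 1 to compound 4 (0.22 log units; that floor lies within the scatter), so of the three groups seen at this carbon only chloro stands apart, and the read-out for hydrogen is bounded on one side only: the limit of > 866 uL/min in this assay, at which 1 of the 4 values shown sits.

The compounds shown leave open whether fluoro, bromo or trifluoromethyl at this carbon would hold the number down as chloro does. They also leave open whether chloro would have the same effect with 4-fluorophenyl in place of 1H-imidazol-2-yl on the carbonyl carbon.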